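Homologous esters on one shared core in a cytotoxicity read-out

The source may report more compounds than this note shows. Statements on the series, on what has been measured and on what is new or still open speak of the compounds shown alone.

Measured compounds:
compound 1, `CCCCCCCCCOC(=O)CCC(=O)N1CCN(CCCOc2cc3c(Nc4ccc(F)c(Cl)c4)ncnc3cc2OC)CC1`, gives 79.7%.
compound 2, `CCCCCCCCCCOC(=O)CCC(=O)N1CCN(CCCOc2cc3c(Nc4ccc(F)c(Cl)c4)ncnc3cc2OC)CC1`, gives 88.2%.
compound 3, `CCCCCCCCCCCCCCCOC(=O)CCC(=O)N1CCN(CCCOc2cc3c(Nc4ccc(F)c(Cl)c4)ncnc3cc2OC)CC1`, gives 91.2%.

All three were tested in a functional assay on A549 cells (Homo sapiens) for cytotoxicity, read by MTT assay, with a stated time of 24 h, tested at 20 uM; on this read-out lower numbers stand for a stronger effect and higher numbers for a weaker effect at the one concentration tested. Compound 1 and compound 3 share a core; how they differ is hexyl in place of hydrogen on a saturated chain carbon, nine bonds along the chain from an oxygen next to a carbonyl group, and the step between them is a number 11.5 percentage points higher from compound 1 to compound 3 (beyond the scatter). Compound 2 sits between them with a number 8.5 percentage points higher from compound 1 to compound 2 (within the scatter) and a number 3 percentage points higher from compound 2 to compound 3 (within the scatter), both of which are within the scatter.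

Compound 4, `CCCCCCCCCCCCCCCCOC(=O)CCC(=O)N1CCN(CCCOc2cc3c(Nc4ccc(F)c(Cl)c4)ncnc3cc2OC)CC1`, is not yet measured. It differs from compound 3 by methyl in place of hydrogen on a saturated chain carbon, ten or more bonds along the chain from an oxygen next to a carbonyl group. The same kind of change was made from compound 1 to compound 2, (methyl in place of hydrogen on a saturated chain carbon, nine bonds along the chain from an oxygen next to a carbonyl group), where the step was a number 8.5 percentage points higher from compound 1 to compound 2 (within the scatter); only the place along the chain differs between the two changes. On the earlier step, which lay within the scatter, compound 4 is expected to show a number 1.8 percentage points higher from compound 3 to compound 4 (within the scatter), because compound 3 already gives 91.2%. Compound 4 is therefore estimated at 93%, between 83% and 100%.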

Compound 4, a percentage reported as activity, at one concentration (the size of the read-out at that concentration, not a potency): 91.7%
For compound 4 the middle estimate is 1.3 percentage points above the measured one, within the range that was stated.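

In this assay, methyl in place of hydrogen on a saturated chain carbon, ten or more bonds along the chain from an oxygen next to a carbonyl group, gave a number 0.5 percentage points higher from compound 3 to compound 4 (within the scatter), and this does not differ measurably from the earlier methyl step: the same change on two cores in this assay, a number 8.5 percentage points higher (within the scatter) from compound 1 to compound 2 and a number 0.5 percentage points higher (within the scatter) from compound 3 to compound 4, 8 percentage points apart, within the scatter of two such steps The hexyl change, with a number 3.5 percentage points higher from compound 2 to compound 4 (within the scatter), likewise agrees with its earlier counterpart: the same change on two cores in this assay, a number 11.5 percentage points higher (beyond the scatter) from compound 1 to compound 3 and a number 3.5 percentage points higher (within the scatter) from compound 2 to compound 4, 8 percentage points apart, within the scatter of two such steps Across these esters, the change therefore carries from one core to another without a difference that can be told from the scatter, and only the longest change, with a number 12 percentage points higher from compound 1 to compound 4 (beyond the scatter), stands beyond it; this does not show that the steps are equal, as each comparison rests on a single pair of steps at one concentration.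

The compounds shown leave open whether a butyl ester or a free carboxylic acid in place of these long esters would fall in line with them. They also leave open whether an amide in place of the ester would do so.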